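The source may hold more compounds than are shown below. What is called first, only, known or untested is meant among the compounds shown, and "the series" means these compounds.

Measured in a functional assay on MCF7 cells (Homo sapiens) for cytotoxicity, read by MTT assay, with a stated time of 24 h; on this read-out higher numbers stand for weaker inhibition and lower numbers for stronger inhibition:
compound 1 `CCNc1cc(-c2ccc(NC(=O)Nc3cccc(Cl)c3)cc2C(F)(F)F)ccn1`: 1240 nM
compound 2 `CCNc1cc(-c2ccc(NC(=O)Nc3ccc(C(F)(F)F)cc3)cc2C(F)(F)F)ccn1`: 2390 nM

Compound 2 stands at 2390 nM. Only compound 1 offers a comparison, and the two values lie within the scatter of each other. Compound 3 `CCNc1cc(-c2ccc(NC(=O)Nc3cccc4ccccc34)cc2C(F)(F)F)ccn1` keeps the rest of compound 2 and changes one group: naphthalen-1-yl in place of 4-(trifluoromethyl)phenyl on an amide-type nitrogen. In words, naphthalen-1-yl stands in place of 4-(trifluoromethyl)phenyl on an amide-type nitrogen whose other neighbour is the carbonyl carbon.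

Among the measured compounds shown here, the only measured step at this place is a 1.9-fold higher number from compound 1 to compound 2 (0.28 log units; within the scatter), with 4-(trifluoromethyl)phenyl in place of 3-chlorophenyl on the same nitrogen. On that evidence, no step beyond the scatter is expected in this assay, in either direction. For the measured compounds named here, the evidence is thin, however, as it is a single step and no measured compound carries naphthalen-1-yl, so the range is kept wide. The expected step reads a 1.3-fold lower number from compound 2 to compound 3 (0.12 log units; within the scatter). Compound 3 is estimated at 1800 nM, with an expected range from 700 nM to 4500 nM.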

Compound 3, half-maximal inhibitory concentration: 16300 nM
The estimate for compound 3 lay 9.1-fold (0.96 log units) below the measured number; measured number outside the range, above it.
By their numbers in this assay, from the lowest: compounds 1 and 2 (each within the scatter of the next); then compound 3.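

In this assay, the group on the amide-type nitrogen whose other neighbour is the carbonyl carbon proves able to shift the result: naphthalen-1-yl in place of 4-(trifluoromethyl)phenyl gives a clear move toward weaker inhibition (a 6.8-fold higher number from compound 2 to compound 3 (0.83 log units; beyond the scatter)), and naphthalen-1-yl in place of 3-chlorophenyl gives a larger one (a 13-fold higher number from compound 1 to compound 3 (1.12 log units; beyond the scatter)). Compound 1 and compound 2 lie within the scatter of each other and showed no such sensitivity, so the two substituted phenyl groups say little about how far this position tolerates change, while compound 3 shows that it does not tolerate every group of the same heavy-atom count, since both the leaving 4-(trifluoromethyl)phenyl and the entering naphthalen-1-yl hold 10 heavy atoms, the latter with 2 six-membered aromatic rings instead of one. Nothing available here bears on why this swap weakens inhibition.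

From the compounds shown here alone, it stays open whether the second ring itself or its manner of attachment goes with the weaker inhibition, and whether naphthalen-2-yl, unsubstituted phenyl or cyclohexyl on the same nitrogen would stay with compound 1 and compound 2 or fall with compound 3. The three compounds also leave open whether the same order would hold in any other cell line or at a longer exposure.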